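The compounds below may be only part of what the source reports. "The series", "measured", "known", "first", "only" and "open" are said of these compounds alone.

- compound 1 `CCC(C)n1ncn(-c2ccc(N3CCN(c4ccc(OC[C@@H]5COC(c6ccc(Cl)cc6Cl)O5)cc4)CC3)cc2)c1=O` gives 328 nM 
- compound 2 `CCC(C)n1ncn(-c2ccc(N3CCN(c4ccc(OC[C@@H]5CO[C@@](CBr)(c6ccc(Cl)cc6Cl)O5)cc4)CC3)cc2)c1=O` gives 569 nM 
- compound 3 `CCC(C)n1ncn(-c2ccc(N3CCN(c4ccc(OC[C@@H]5CO[C@@](CC6CCCC6)(c6ccc(Cl)cc6Cl)O5)cc4)CC3)cc2)c1=O` gives 512 nM 

These three numbers come from a functional assay on HUVEC cells (Homo sapiens), read by scintillation counting and thymidine incorporation, with a stated time of 24 h (a higher number here means a weaker inhibitor, a lower number a stronger inhibitor), and lie close together. Compound 3 at 512 nM stands within the scatter of both compound 1 and compound 2, so the data do not separate it from either.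

The next compound to be measured is compound 4 `CCC(C)n1ncn(-c2ccc(N3CCN(c4ccc(OC[C@@H]5CO[C@@](CN(C)C)(c6ccc(Cl)cc6Cl)O5)cc4)CC3)cc2)c1=O`, which keeps the rest of compound 3 and alters one group. The difference is dimethylamino in place of cyclopentyl on a saturated chain carbon bound to a saturated ring carbon and it reads, in words, as dimethylamino in place of cyclopentyl on a saturated chain carbon bound to a saturated ring carbon.

Among the measured compounds shown here, one measured step touches this place. It is a 1.1-fold lower number from compound 2 to compound 3 (0.05 log units; within the scatter) and it swaps bromo for cyclopentyl. That swap left the number in this assay unmoved beyond the scatter, which suggests some tolerance for change here. For the measured compounds named here, still, neither group resembles dimethylamino, and no measured compound carries an amine at this place, so the evidence is thin.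

No step beyond the scatter is therefore expected, and no direction can be favoured. The estimate amounts to a 1.0-fold lower number from compound 3 to compound 4 (0.01 log units; within the scatter) as the expected step. For compound 4 the estimated value is 500 nM with an expected range from 220 nM to 1150 nM as its limits.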

Compound 4, half-maximal inhibitory concentration: 1400 nM
Compound 4: the middle estimate sits 2.8-fold (0.45 log units) below what was measured; measured number outside the range, above it.
By their numbers in this assay, from the lowest: compounds 1, 3 and 2 (each within the scatter of the next); then compound 4.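

Among the groups measured at this place, on a saturated chain carbon bound to a saturated ring carbon, dimethylamino is the first to move the number beyond the scatter in this assay, with a 2.7-fold higher number from compound 3 to compound 4 (0.44 log units; beyond the scatter) and a 2.5-fold higher number from compound 2 to compound 4 (0.39 log units; beyond the scatter). So the tolerance suggested by the match between bromo and cyclopentyl does not extend to every group, and in these compounds the change runs towards a weaker inhibitor. Compared with cyclopentyl, dimethylamino has fewer heavy atoms, no ring, and a nitrogen that counts as one hydrogen-bond acceptor, but no measurement here shows which of these differences matters.

The compounds shown leave open whether the nitrogen or the loss of the ring goes with the higher number, and a single amine cannot settle that. An isopropyl group, with carbon only and no ring, would test the ring without the nitrogen, while a pyrrolidine ring attached through its nitrogen would test the nitrogen with a ring kept in place.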